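A Halogen Swap Repeated on a Second Core

The compounds below may be only part of what the source reports. "The series", "measured", "known", "first", "only" and "open" are said of these compounds alone.

Compound 1, `O/N=C(/Nc1cccc(Cl)c1)c1ccc2occc2c1`, gives 1500 nM in an assay on tissue (HeLa cells) for inhibition of Indoleamine 2,3-dioxygenase 1 (Homo sapiens), read by spectrophotometry; on this read-out higher numbers stand for weaker inhibition and lower numbers for stronger inhibition.
Compound 2, `O/N=C(/Nc1cccc(Br)c1)c1ccc2occc2c1`, gives 1100 nM in this assay.
Compound 3, `COCc1cc2cc(/C(=N\O)Nc3cccc(Cl)c3)ccc2o1`, gives 2200 nM in this assay.

Of the compounds shown here, three have been measured. Compound 2 differs from compound 1 by bromo in place of chloro on an aromatic carbon, and this change made a step of a 1.4-fold lower number from compound 1 to compound 2 (0.13 log units; within the scatter). Compound 3 differs from compound 1 in its core by methoxymethyl in place of hydrogen on an aromatic carbon, and that change made a step of a 1.5-fold higher number from compound 1 to compound 3 (0.17 log units; within the scatter). Compound 3 therefore sits at the highest of the three numbers, but its separation from compound 1 and from compound 2 is within the scatter, so no order among the three can be claimed.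

The unmeasured compound 4, `COCc1cc2cc(/C(=N\O)Nc3cccc(Br)c3)ccc2o1`, differs from compound 3 by bromo in place of chloro on an aromatic carbon. Within the data shown here, this is the same change as the one from compound 1 to compound 2, made here on the core of compound 3, and the place of the change is described in the same words in both pairs.

Among the measured compounds shown here, for compound 4 a step of a 1.4-fold lower number from compound 3 to compound 4 (0.14 log units; within the scatter) is expected in this assay because a 1.4-fold lower number from compound 1 to compound 2 (0.13 log units; within the scatter) is the only measured instance of this change, and there is nothing in the data to suggest the core of compound 3 would receive it differently. The expectation rests on a single pair, so the range is kept wide. Compound 4 is estimated at 1600 nM, between 700 nM and 3500 nM.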

Compound 4, half-maximal inhibitory concentration: 2500 nM
The estimate for compound 4 lay 1.6-fold (0.19 log units) below the measured number; measured number inside the range.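

In this assay, bromo in place of chloro on the core of compound 3 gave a 1.1-fold higher number from compound 3 to compound 4 (0.06 log units; within the scatter), and this step agrees with the earlier one on the core of compound 1: the same change on two cores in this assay, a 1.4-fold lower number (0.13 log units; within the scatter) from compound 1 to compound 2 and a 1.1-fold higher number (0.06 log units; within the scatter) from compound 3 to compound 4, 1.5-fold (0.19 log units) apart, within the scatter of two such steps. Methoxymethyl in place of hydrogen, now carried on the bromo series, gave a 2.3-fold higher number from compound 2 to compound 4 (0.36 log units; beyond the scatter), which lies beyond the scatter where its chloro counterpart did not, yet the two steps still cannot be told apart: the same change on two cores in this assay, a 1.5-fold higher number (0.17 log units; within the scatter) from compound 1 to compound 3 and a 2.3-fold higher number (0.36 log units; beyond the scatter) from compound 2 to compound 4, 1.5-fold (0.19 log units) apart, within the scatter of two such steps. So both changes carried from one core to the other without a detectable difference in step size, but this rests on only two pairs for each change, and the halogen steps are too small to show any real effect of that swap on either core, so a constant contribution from either change is not established.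

The compounds shown leave open whether an amine or a carboxylic acid on the phenyl ring, where the steps might be large enough to read clearly, would carry between the two cores in the same way. They also leave open how a longer chain in place of methoxymethyl would read in this assay.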